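Chloro to phenyl at the para position: lipophilicity outlook

A few compounds are considered here, and "the series" means these few. Any claim that something is new, unique, unknown or untested is made for them only; others in the source may bear on it.

Among the compounds with values here, the series so far holds compound 1 `O=C(O)CC(CC(=O)NNC(=O)CCCCNc1ccccn1)c1ccc(F)cc1` and compound 2 `O=C(O)CC(CC(=O)NNC(=O)CCCCNc1ccccn1)c1ccc(Cl)cc1`. In a physicochemical assay for lipophilicity (on this read-out higher numbers stand for higher lipophilicity and lower numbers for lower lipophilicity), compound 1 gives 2.23, and in this assay compound 2 gives 2.63. Within the data shown here, compound 2 is thus the higher of the two numbers measured, and the single step between them, a number 0.40 log units higher from compound 1 to compound 2 (beyond the scatter), is the only change at this position recorded so far.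

Compound 3 `O=C(O)CC(CC(=O)NNC(=O)CCCCNc1ccccn1)c1ccc(-c2ccccc2)cc1` is not yet measured. It differs from compound 2 by phenyl in place of chloro on an aromatic carbon.

Among the measured compounds shown here, only one measured step bears on this change: a number 0.40 log units higher from compound 1 to compound 2 (beyond the scatter), where a chloro in place of a fluoro at the same aromatic carbon raised the number by a modest amount. For the measured compounds named here, no measured pair shows chloro giving way to phenyl, so the size of the coming step rests on a single precedent and on the larger group entering. A rise clearly beyond the scatter is expected in this assay, larger than the earlier one.

For compound 3 the estimate in this assay is 3.85, with a range from 3.3 to 4.4, which corresponds to an expected step of a number 1.22 log units higher from compound 2 to compound 3 (beyond the scatter).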

Compound 3, partition coefficient: 3.74
Estimate against measurement, compound 3: 0.11 log units above; measured number inside the range.
By their numbers in this assay, from the lowest: compound 1; then compound 2; then compound 3.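

In this assay the exchange of chloro for phenyl gives a large step (a number 1.11 log units higher from compound 2 to compound 3 (beyond the scatter)), whereas the exchange of fluoro for chloro gave a modest one (a number 0.40 log units higher from compound 1 to compound 2 (beyond the scatter)), so a single aromatic carbon accommodates changes of clearly different size on this read-out. Across the whole set, the position spans a large range (a number 1.51 log units higher from compound 1 to compound 3 (beyond the scatter)) with the rest of the structure held constant, and the order fluoro, chloro, phenyl holds for all three compounds, with none going against it. Nothing available accounts for the size of these steps.

Chloro gives way to a group with more heavy atoms and a ring, so these compounds cannot separate the contribution of the ring from that of the added atoms, and cyclohexyl, pyridyl or a phenyl carrying an amine would each test that in a different way. From the compounds shown here alone, all three compounds also share the same carboxylic acid and the same chain, so whether the steps at this position keep their size with an ester in place of that acid, or with a shorter chain, remains open.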